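The compounds below may be only part of what the source reports. "The series", "measured", "known", "first", "only" and "open" are said of these compounds alone.

Working notes, measured in a functional assay on MDA-MB-231 cells (Homo sapiens) for inhibition, read by MTT assay, with a stated time of 24 h; on this read-out higher numbers stand for weaker inhibition of growth and lower numbers for stronger inhibition of growth:

- compound 1 `N[C@@H](CCC(=O)OC[C@H]1O[C@@H](n2cc(F)c(=O)[nH]c2=O)C[C@@H]1OC(=O)CC[C@H](N)C(=O)O)C(=O)O`: 37300000 nM
- compound 2 `N[C@@H](CC(=O)OC[C@H]1O[C@@H](n2cc(F)c(=O)[nH]c2=O)C[C@@H]1O)C(=O)O`: 29300000 nM

Compound 2 (29300000 nM) lies within the usual scatter of compound 1 (37300000 nM), so the two cannot be separated on these numbers, and both values are very high on this read-out.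

Compound 3 `N[C@@H](CC(=O)OC[C@H]1O[C@@H](n2cc(F)c(=O)[nH]c2=O)C[C@@H]1OC(=O)C[C@H](N)C(=O)O)C(=O)O` differs from compound 2 in one place: (2-amino-2-carboxyethyl)carbonyl in place of hydrogen on an oxygen on a saturated carbon.

For the measured compounds named here, the data hold no measured step for a change made in one place, so the size of this step cannot be read from the series. Going by the values given here, the only guide is the narrow spread of the two values, with compound 1 at (37300000 nM) and compound 2 at (29300000 nM). In this assay no step beyond the scatter is expected, in either direction. The expected change is small: a 1.1-fold higher number from compound 2 to compound 3 (0.05 log units; within the scatter).

For compound 3 the estimated value is 33000000 nM, with an expected range from 15000000 nM to 70000000 nM.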

Compound 3, concentration for 50% growth inhibition: 33100000 nM
Beside the measured number, compound 3's estimate is 1.0-fold (0.00 log units) below it; the range from low to high includes it.
By their numbers in this assay, from the lowest: compounds 2, 3 and 1 (each within the scatter of the next).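

In this assay, the step at this position reads a 1.1-fold higher number from compound 2 to compound 3 (0.05 log units; within the scatter). For the compounds shown here, it is the first change in one place that can be read: hydroxy gives way to ((2-amino-2-carboxyethyl)carbonyl)oxy, on an oxygen on a saturated carbon, and an entering group of 8 heavy atoms with 1 defined stereocentre does not separate compound 3 from compound 2 on this read-out. No measurement on these compounds offers any explanation of this result.

The compounds shown leave open whether any other group on this oxygen, such as a plain acetyl ester, a methyl ether or a benzoyl ester, would give a step beyond the scatter. They also leave open whether a change on the shared core elsewhere, for example an amide in place of the ester link on the other oxygen, would move the number away from the very high values seen so far.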